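The source may hold more compounds than are shown below. What is called first, only, known or untested is meant among the compounds shown, and "the series" means these compounds.

Measured compounds:
- Compound 2, `ClCc1ccccc1Cn1cnc2c(Cl)ncnc21`: 24600 nM
- Compound 3, `ClCc1cccc(Cn2cnc3ncnc(Cl)c32)c1`: 42700 nM
- Compound 1, `ClCc1ccccc1Cn1cnc2c(Cl)nc(Cl)nc21`: "not determined" (no result reported)

Compound 3 and compound 2 were both tested in a functional assay on SK-MEL-28 cells (Homo sapiens) for cytotoxicity, read by sulforhodamine B assay, with a stated time of 48 h; a higher number here means that more compound is tolerated, a lower number that less compound is tolerated. Compound 3 gives 42700 nM, the higher of the two numbers, while compound 2 gives 24600 nM, but the two lie within the usual scatter of each other, so no order between them can be read from these figures. Compound 1, which carries a second chloro group on the core, has no result in this assay, so nothing is known here about what a second chloro does.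

Compound 4, `ClCc1cccc(Cn2cnc3nc(Cl)nc(Cl)c32)c1`, is the next compound. It differs from compound 3 in one place: chloro in place of hydrogen on an aromatic carbon. Among the compounds with values here, since no comparable step between measured compounds is available, there is no basis for expecting a change beyond the scatter in either direction. The estimate for compound 4 in this assay is therefore close to compound 3, with a step of a 1.2-fold lower number from compound 3 to compound 4 (0.09 log units; within the scatter) expected, and a value of 35000 nM expected, within a range from 10000 nM to 100000 nM.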

Compound 4, concentration lethal to 50% of the cells: 970 nM
For compound 4 the middle estimate is 36-fold (1.56 log units) above the measured one; measured number below the stated range.
By their numbers in this assay, from the lowest: compound 4; then compounds 2 and 3 (each within the scatter of the next).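

The earlier compounds shown here gave no reading of this position, as compound 1 has no number. In this assay the position now proves far from indifferent: on the aromatic carbon between two ring nitrogen atoms, chloro in place of hydrogen gives a 44-fold lower number from compound 3 to compound 4 (1.64 log units; beyond the scatter), well beyond the scatter, so one added chlorine atom is enough to make compound 4 clearly the least tolerated of the measured compounds. Nothing measured here says why this single change has so large an effect.

On these data alone, the step rests on one pair only, and with no number for compound 1, it remains open whether the same chloro would matter as much on compound 2. Also open, as far as these compounds go, is whether an amine, a methoxy group or a fluoro at this position would give a similar number.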